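Shortening the amine ring on a long ether chain

The compounds below may be only part of what the source reports. "The series", "measured", "known", "first", "only" and "open" are said of these compounds alone.

Measured compounds:
compound 1, `COc1cc(/C=C/C(=O)Nc2ccccc2)ccc1OCCCN1CCCCC1`, 1.58
compound 2, `COc1cc(/C=C/C(=O)Nc2ccccc2)ccc1OCCCN1CCCC1`, 1.57
compound 3, `COc1cc(/C=C/C(=O)Nc2ccccc2)ccc1OCCCCCCCCCCN1CCCCC1`, 1.83

In a physicochemical assay for lipophilicity, using the shake flask method, measured as octanol-water partition, at pH 7.4 (on this read-out higher numbers stand for higher lipophilicity and lower numbers for lower lipophilicity), compound 1 gives 1.58, compound 2 gives 1.57 and compound 3 gives 1.83. The change pyrrolidin-1-yl in place of piperidin-1-yl on a saturated chain carbon, three bonds along the chain from an oxygen on an aromatic ring made a number 0.01 log units lower from compound 1 to compound 2 (within the scatter). Compound 4, `COc1cc(/C=C/C(=O)Nc2ccccc2)ccc1OCCCCCCCCCCN1CCCC1`, carries the same kind of change, (pyrrolidin-1-yl in place of piperidin-1-yl on a saturated chain carbon, ten or more bonds along the chain from an oxygen on an aromatic ring), on the core of compound 3; the difference between the two cores is not broken down here. The two changes differ only in how far along the chain from the oxygen on the aromatic ring they sit. Because the earlier step of a number 0.01 log units lower from compound 1 to compound 2 (within the scatter) lay within the scatter, compound 4 is expected to show a number 0.01 log units lower from compound 3 to compound 4 (within the scatter). Compound 4 is estimated at 1.82, between 1.55 and 2.1.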

Compound 4, partition coefficient: 1.86
For compound 4 the middle estimate is 0.04 log units below the measured one, and the stated range covers the measured number.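

In this assay the swap of piperidin-1-yl for pyrrolidin-1-yl gave a number 0.03 log units higher from compound 3 to compound 4 (within the scatter) and the earlier step gave a number 0.01 log units lower from compound 1 to compound 2 (within the scatter) on the shorter chain, which places the change within the scatter on both cores. Among the compounds shown here, this shows that for these two pairs the change carried from one core to the other with no step that can be told from the scatter, but two pairs do not show that it would behave the same way on any other core. Nothing measured here offers a reason for either step.

The compounds shown leave open how another amine, such as morpholin-4-yl or 4-methylpiperazin-1-yl, would read on these same chains. On these data alone, a longer chain also remains open.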